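Methyl to Nitrooxy: Expected Cytotoxicity of Compound 4

A few compounds are considered here, and "the series" means these few. Any claim that something is new, unique, unknown or untested is made for them only; others in the source may bear on it.

Measured so far:
compound 1 `Cc1ccc(S(=O)(=O)N2C/C(=C\c3cccc(F)c3)C(=O)/C(=C/c3cccc(F)c3)C2)cc1`, 15700 nM
compound 2 `O=C1/C(=C/c2cccc(F)c2)CN(S(=O)(=O)c2ccc(O[N+](=O)[O-])cc2)C/C1=C\c1cccc(F)c1`, 10700 nM
compound 3 `Cc1ccc(S(=O)(=O)N2C/C(=C\c3ccc(F)cc3)C(=O)/C(=C/c3ccc(F)cc3)C2)cc1`, 14000 nM

These numbers come from an ADME assay on L02 cells (Homo sapiens) for cytotoxicity, read by MTT assay, with a stated time of 24 h; on this read-out higher numbers stand for weaker inhibition and lower numbers for stronger inhibition. Compound 1 and compound 3 contain the same atoms joined differently; the difference between the two cores is not broken down here. Their values in this assay lie within the scatter of each other, so neither can be called the stronger. Compound 2 differs from compound 1 by nitrooxy in place of methyl on an aromatic carbon, and this gave a 1.5-fold lower number from compound 1 to compound 2 (0.17 log units; within the scatter). Compound 4 `O=C1/C(=C/c2ccc(F)cc2)CN(S(=O)(=O)c2ccc(O[N+](=O)[O-])cc2)C/C1=C\c1ccc(F)cc1` has not yet been measured; it carries the same change, (nitrooxy in place of methyl on an aromatic carbon), on the core of compound 3. Because the earlier step of a 1.5-fold lower number from compound 1 to compound 2 (0.17 log units; within the scatter) was small, the step expected for compound 4 is of similar size, a 1.4-fold lower number from compound 3 to compound 4 (0.15 log units; within the scatter). Compound 4 is therefore estimated at 10000 nM, most likely between 5000 nM and 20000 nM.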

Compound 4, half-maximal inhibitory concentration: 16200 nM
Compound 4: middle estimate off by 1.6-fold (0.21 log units), on the low side; measured number inside the range.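

In this assay, among these compounds, nitrooxy in place of methyl gave a 1.2-fold higher number from compound 3 to compound 4 (0.06 log units; within the scatter) and so produced no step that stands clear of the usual scatter. This does not show that the change moves the number in either direction on either core, and two cores cannot speak for the rest of the series. As far as these data can tell, the change behaves alike on both cores: the same change on two cores in this assay, a 1.5-fold lower number (0.17 log units; within the scatter) from compound 1 to compound 2 and a 1.2-fold higher number (0.06 log units; within the scatter) from compound 3 to compound 4, 1.7-fold (0.23 log units) apart, within the scatter of two such steps

The compounds shown leave open whether another group on that aromatic carbon, such as an amine or a carboxylic acid, would give a step beyond the scatter. They also leave open how the change would behave with substituents other than fluorine on the outer rings.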